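A few compounds are considered here, and "the series" means these few. Any claim that something is new, unique, unknown or untested is made for them only; others in the source may bear on it.

Measured in a functional assay on A549 cells (Homo sapiens) for cytotoxicity; a higher number here means a weaker inhibitor, a lower number a stronger inhibitor:
- compound 1 `C=C/C=C\[C@H](C)[C@H](OC(N)=O)[C@@H](C)[C@H](O)[C@@H](C)C/C(C)=C\[C@H](C)[C@@H](O)[C@@H](C)/C=C\CCc1ccc(Oc2ccccc2)cc1`: 10000 nM
- compound 2 `C=C/C=C\[C@H](C)[C@H](OC(N)=O)[C@@H](C)[C@H](O)[C@@H](C)C/C(C)=C\[C@H](C)[C@@H](O)[C@@H](C)/C=C\CCc1ccc(C)c(F)c1`: 4000 nM
- compound 3 `C=C/C=C\[C@H](C)[C@H](OC(N)=O)[C@@H](C)[C@H](O)[C@@H](C)C/C(C)=C\[C@H](C)[C@@H](O)[C@@H](C)/C=C\CCc1ccc(C)c(O)c1`: 4000 nM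

Compound 3 stands level with compound 2, and these two share the lowest number of the three. Compound 1 has the highest number, at 10000 nM.

Next in the series is compound 4 `C=C/C=C\[C@H](C)[C@H](OC(N)=O)[C@@H](C)[C@H](O)[C@@H](C)C/C(C)=C\[C@H](C)[C@@H](O)[C@@H](C)/C=C\CCc1cccc(OC)c1`, which carries 3-methoxyphenyl in place of 3-hydroxy-4-methylphenyl on a saturated chain carbon, two bonds along the chain from a double-bonded chain carbon.

Among the measured compounds shown here, no measured step covers this exchange directly. The nearest evidence is no change at the digits printed from compound 2 to compound 3 (within the scatter), hydroxy in place of fluoro on an aromatic carbon, which stays within the scatter. That is a single step, so it offers only weak support. The values of compounds 1 to 3 nevertheless give a plausible span for the estimate.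

The expected outcome is no shift beyond the scatter, with the estimated step being no change at the digits printed from compound 3 to compound 4 (within the scatter). For compound 4 the estimated value is 4000 nM, with an expected range from 1800 nM to 10000 nM.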

Compound 4, half-maximal inhibitory concentration: 600 nM
For compound 4 the middle estimate is 6.7-fold (0.82 log units) above the measured one, and the stated range ends above it.
By their numbers in this assay, from the lowest: compound 4; then compounds 2 and 3 (each within the scatter of the next); then compound 1.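

In this assay the aryl group on this saturated chain carbon can move the number beyond the scatter: the exchange from 3-hydroxy-4-methylphenyl to 3-methoxyphenyl gives a 6.7-fold lower number from compound 3 to compound 4 (0.82 log units; beyond the scatter) and the exchange from 3-fluoro-4-methylphenyl to 3-methoxyphenyl gives a 6.7-fold lower number from compound 2 to compound 4 (0.82 log units; beyond the scatter) as well. The hydroxy-for-fluoro step alone stayed within the scatter, so the position is not flat across all aryl groups shown. Nothing measured here accounts for the shift.

Compound 4 differs from compound 3 both in the methyl group and in hydroxy against methoxy, and no compound shown separates these two parts of the exchange. Also open, on these data alone, is how this assay would read for an amine or a carboxylic acid on the same aromatic ring, or for a longer chain leading to it.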